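Diethylamino for methyl(propyl)amino near the assay limit

This account rests on a few compounds, and the source may have more. Where it says the series, first, only, none or still open, it means among the compounds named here.

In an ADME assay on MT4 cells (Homo sapiens) for cytotoxicity, read by MTT assay, with a stated time of 4 days (a lower number here means that less compound is tolerated, a higher number that more compound is tolerated), compound 1 `Cc1c(Cc2c(F)cccc2F)nc(N(C)C(C)C)[nH]c1=O` gives 79000 nM. Compound 2 `CCCN(C)c1nc(Cc2c(F)cccc2F)c(C)c(=O)[nH]1` reads > 81000 nM, which is a limit of the assay and not a number, and it stands at the limit of > 81000 nM in this assay, at which 1 of the 2 values shown sits. Among the measured compounds shown here, the one measured step that bears on what follows, propyl in place of isopropyl on a nitrogen on an aromatic ring, is an at least 1.0-fold higher number from compound 1 to compound 2 (0.01 log units; that floor lies within the scatter). Compound 3 `CCN(CC)c1nc(Cc2c(F)cccc2F)c(C)c(=O)[nH]1` carries diethylamino in place of methyl(propyl)amino on an aromatic carbon. The expected change is a step that the limit leaves unreadable from compound 2 to compound 3, with no shift beyond the scatter in either direction. Compound 3 is estimated at 85000 nM, within an expected range of 45000 nM to 160000 nM.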

Compound 3, half-maximal cytotoxic concentration: > 81000 nM
Compound 3 was reported as a limit (the forecaster's own chance of this, stated with the estimate: 55%); the middle value lies beyond the limit too.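

In this assay, diethylamino on this aromatic carbon is a second amine at the limit, so the step between compound 2 and compound 3 cannot be read. Among the compounds shown here, the only readable step is an at least 1.0-fold higher number from compound 1 to compound 3 (0.01 log units; that floor lies within the scatter). The two arrangements of the same atoms therefore end at the same limit, which is not a number: the limit of > 81000 nM in this assay, at which 2 of the 3 values shown sit.

As far as these compounds go, how much compound is tolerated past that limit remains open for compound 2 and compound 3. Also open, from the compounds shown here alone, is whether a ring amine such as pyrrolidine or morpholine, or a longer chain such as dipropylamino, would give a readable value at this position.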